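Triazolyl Sulfonamides: Predicting an Untested Analogue's Potency

A few compounds are considered here, and "the series" means these few. Any claim that something is new, unique, unknown or untested is made for them only; others in the source may bear on it.

Compound 1 `Cc1ccc(-n2cc(-c3ccccc3NS(=O)(=O)c3c[nH]c(=O)[nH]c3=O)nn2)cc1`: 8350 nM
Compound 2 `O=c1[nH]cc(S(=O)(=O)Nc2ccccc2-c2cn(-c3ccccc3F)nn2)c(=O)[nH]1`: 12500 nM
Compound 3 `Cc1ccc(-n2cc(-c3ccc(NS(=O)(=O)c4c[nH]c(=O)[nH]c4=O)cc3)nn2)cc1`: 11600 nM

Three compounds were examined in a functional assay on HepG2 cells (Homo sapiens) for antiproliferative activity, read by MTT assay, with a stated time of 24 h; a higher number here means a weaker inhibitor, a lower number a stronger inhibitor. Compound 1 gives 8350 nM in this assay, compound 2 gives 12500 nM, and compound 3 gives 11600 nM. The three numbers lie close to one another; the values of compound 2 and compound 3 in particular differ by so little that no order between them can be read.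

Compound 1 and compound 2 share a core and differ in one place: 2-fluorophenyl in place of 4-methylphenyl on an aromatic nitrogen. This change made a 1.5-fold higher number from compound 1 to compound 2 (0.18 log units; within the scatter). Compound 3 has the same atoms as compound 1 joined differently; the difference between the two cores is not broken down here.

Compound 4 `O=c1[nH]cc(S(=O)(=O)Nc2ccc(-c3cn(-c4ccccc4F)nn3)cc2)c(=O)[nH]1` has not yet been measured. It stands to compound 3 as compound 2 stands to compound 1: 2-fluorophenyl in place of 4-methylphenyl on an aromatic nitrogen, at a place described in the same words, so the change is the same. Because the earlier step of a 1.5-fold higher number from compound 1 to compound 2 (0.18 log units; within the scatter) was small, the step from compound 3 to compound 4 is expected to be of similar size, a 1.3-fold higher number from compound 3 to compound 4 (0.11 log units; within the scatter), in this assay. Compound 4 is therefore estimated to give 15000 nM in this assay, plausibly between 7000 nM and 35000 nM.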

Compound 4, half-maximal inhibitory concentration: > 20000 nM
Compound 4 ended at the assay's limit; the forecaster's own chance of this, stated with the estimate: 10%; at least 1.3-fold (0.12 log units) between middle value and limit.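

In this assay compound 4 gives > 20000 nM, which is a limit of the assay and not a measured number. Placing 2-fluorophenyl where 4-methylphenyl stood on the core of compound 3 therefore yields only a floor, an at least 1.7-fold higher number from compound 3 to compound 4 (0.23 log units; that floor lies within the scatter), and on the core of compound 1 the same change gave a 1.5-fold higher number from compound 1 to compound 2 (0.18 log units; within the scatter). This pair of steps is consistent with the change carrying over from one core to the other, but it does not establish that it does, since the true size of the second step remains unknown, and the comparison stands as follows: the same change on two cores in this assay, a 1.5-fold higher number (0.18 log units; within the scatter) from compound 1 to compound 2 and an at least 1.7-fold higher number (0.23 log units; that floor lies within the scatter) from compound 3 to compound 4; the limit leaves it open whether they differ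

The compounds shown leave open how large the step on the core of compound 3 really is, and whether on either core the change has any effect that rises beyond the usual scatter of this kind of measurement. They also leave open whether the two cores would respond alike to other groups on that aromatic nitrogen, such as an unsubstituted phenyl, a 4-methoxyphenyl or a benzyl group, since only 4-methylphenyl and 2-fluorophenyl appear there in this set.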